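Methoxy on the sulfonyl phenyl of a quinoxaline sulfone

A few compounds are considered here, and "the series" means these few. Any claim that something is new, unique, unknown or untested is made for them only; others in the source may bear on it.

The measured compounds so far:
Compound 1 `COc1cc(Nc2nc3ccccc3nc2S(=O)(=O)c2ccccc2)cc(OC)c1` gives 70 nM in a functional assay on A549 cells (Homo sapiens) for cytotoxicity, read by MTT assay, with a stated time of 72 h; a lower number here means a stronger inhibitor, a higher number a weaker inhibitor.
Compound 2 `O=S(=O)(c1ccccc1)c1nc2ccccc2nc1Nc1ccc(Cl)cc1` gives 30700 nM in this assay.
Compound 3 `O=S(=O)(c1ccccc1)c1nc2ccccc2nc1Nc1ccc(C(F)(F)F)cc1` reaches only a limit of the assay, > 50000 nM, in this assay, and that limit is the limit of > 50000 nM in this assay, at which 1 of the 3 values shown sits.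

Compound 2 holds the highest of the two numbers that were read; its nearest neighbour is compound 1, with a 440-fold higher number from compound 1 to compound 2 (2.64 log units; beyond the scatter). Compound 4 `COc1ccc(S(=O)(=O)c2nc3ccccc3nc2Nc2ccc(Cl)cc2)cc1` differs from compound 2 in one place: methoxy in place of hydrogen on an aromatic carbon. Among the compounds with values here, none of the measured steps touches this part of the shared core. Every one of them, a 440-fold higher number from compound 1 to compound 2 (2.64 log units; beyond the scatter), an at least 710-fold higher number from compound 1 to compound 3 (2.85 log units; beyond the scatter) and an at least 1.6-fold higher number from compound 2 to compound 3 (0.21 log units; that floor lies within the scatter), changes the group on the nitrogen instead, so they give no direct guide to what a methoxy on the other ring does. Within the data shown here, with no step to lean on, the expectation is a change of modest size, in either direction, for compound 4, with a 1.0-fold lower number from compound 2 to compound 4 (0.01 log units; within the scatter). Compound 4 is therefore estimated at 30000 nM in this assay, with a range from 8000 nM to 100000 nM, and a real chance that only a limit is reported.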

Compound 4, half-maximal inhibitory concentration: 87300 nM
For compound 4 the middle estimate is 2.9-fold (0.46 log units) below the measured one; the measured number falls inside the stated range.
By their numbers in this assay, from the lowest: compound 1; then compound 2; then compound 4.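

Within the data shown here, compound 4 gives the first measured step on the phenyl ring of the sulfone, since every earlier step changed the group on the nitrogen. In this assay the methoxy, para to a large group, gives a 2.8-fold higher number from compound 2 to compound 4 (0.45 log units; beyond the scatter) and so makes this one compound a weaker inhibitor, a far smaller move than a 440-fold higher number from compound 1 to compound 2 (2.64 log units; beyond the scatter) from changing the group on the nitrogen. Compound 3 cannot be placed in the order of these numbers, as its value is only a limit: the limit of > 50000 nM in this assay, at which 1 of the 4 values shown sits.

Going by these compounds, whether the same methoxy would shift the much stronger compound 1 in the same way remains open. So does how an amine, a carboxylic acid or a longer chain such as ethoxy would read at this place on the ring.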